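This account rests on a few compounds, and the source may have more. Where it says the series, first, only, none or still open, it means among the compounds named here.

Measured so far in a functional assay on NCI-H460 cells (Homo sapiens) for cytotoxicity, read by MTT assay, with a stated time of 72 h; on this read-out higher numbers stand for weaker inhibition and lower numbers for stronger inhibition:
- compound 1 `CN(C)Cc1ccc2nc(NC(=O)N/N=C/c3cn(Cc4ccccc4Cl)c4ccccc34)sc2c1`: 1600 nM
- compound 2 `CCN(CC)Cc1ccc2nc(NC(=O)N/N=C/c3cn(Cc4ccc(C)cc4)c4ccccc34)sc2c1`: 320 nM

Compound 2 holds the lower of the two numbers, and so the stronger inhibition. Its gap to compound 1 lies beyond the scatter. Among the measured compounds shown here, no two measured compounds differ in one place only, so no single-change step is available as a guide.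

The next compound is compound 3 `CCN(CC)Cc1ccc2nc(NC(=O)N/N=C/c3cn(Cc4ccccc4Cl)c4ccccc34)sc2c1`. The change from compound 2 is 2-chlorophenyl in place of 4-methylphenyl on a saturated chain carbon bound to an aromatic nitrogen, with 2-chlorophenyl in place of 4-methylphenyl on a saturated chain carbon bound to an aromatic nitrogen.

Among the measured compounds, 2-chlorophenyl occurs only in compound 1, at 1600 nM, while compound 2 stands at 320 nM. On this thin evidence, a move towards a higher number in this assay is expected, of a size close to the scatter, and no change beyond the scatter remains possible. The expected step is a 1.9-fold higher number from compound 2 to compound 3 (0.27 log units; within the scatter). For compound 3 the estimated value is 600 nM, with an expected range of 200 nM to 1800 nM.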

Compound 3, half-maximal inhibitory concentration: 980 nM
For compound 3 the middle estimate is 1.6-fold (0.21 log units) below the measured one; the measured number falls inside the stated range.
By their numbers in this assay, from the lowest: compound 2; then compounds 3 and 1 (each within the scatter of the next).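

In this assay, among the compounds shown here, the pair compound 2 and compound 3 gives the first single-change reading at the position on a saturated chain carbon bound to an aromatic nitrogen: 2-chlorophenyl in place of 4-methylphenyl gives a 3.1-fold higher number from compound 2 to compound 3 (0.49 log units; beyond the scatter) with diethylamino held constant, so this position responds to the change of aryl group. The second new reading concerns the position on a saturated chain carbon bound to an aromatic carbon, where diethylamino in place of dimethylamino gives a 1.6-fold lower number from compound 1 to compound 3 (0.21 log units; within the scatter) with 2-chlorophenyl held constant, so the two amines cannot be told apart in this setting. For the compounds shown here, nothing measured so far accounts for either step.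

Since the aryl change alters both the substituent and its place on the ring, the compounds shown cannot separate the contribution of the chlorine from that of the methyl, and plain phenyl or a fluorine in place of the chlorine would be needed to begin that separation. On these data alone, it also remains open whether the two amines stay indistinguishable alongside 4-methylphenyl, and how a cyclic amine such as morpholine or pyrrolidine would read at that position.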